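The compounds below may be only part of what the source reports. "The series", "measured", "known", "first", "only" and "open" are said of these compounds alone.

Compound 1 `CCN(CC)C(=O)Cn1c(=N)sc2cc(OC(F)(F)F)ccc21`: 9 mg/kg
Compound 2 `CS(=O)(=O)CCn1c(=N)sc2cc(OC(F)(F)F)ccc21`: 1.8 mg/kg
Compound 3 `N=c1sc2cc(OC(F)(F)F)ccc2n1CC[S+]([O-])c1ccccc1`: 4.2 mg/kg

In a functional assay on the whole organism with Rattus norvegicus as the target (on this read-out lower numbers stand for an effect already at smaller amounts and higher numbers for an effect only at larger amounts of compound), compound 3 stands second highest of the three numbers, with compound 1 higher and compound 2 lower. Compound 4 `CN(C)CCn1c(=N)sc2cc(OC(F)(F)F)ccc21` carries dimethylamino in place of the aromatic ring-bearing group of compound 3, on a saturated chain carbon, two bonds along the chain from an aromatic nitrogen: a group of 3 heavy atoms (2 carbon, 1 nitrogen; no ring) in place of a group of 8 heavy atoms (6 carbon, 1 oxygen, 1 sulfur; one six-membered aromatic ring of carbon only), on a saturated chain carbon, two bonds along the chain from an aromatic nitrogen. Within the data shown here, two measured steps bear on this change, a 5.0-fold lower number from compound 1 to compound 2 (0.70 log units; beyond the scatter) and a 2.3-fold higher number from compound 2 to compound 3 (0.37 log units; beyond the scatter), and both are modest. Neither brings in dimethylamino, and the data fix no direction. The expected step, a 1.2-fold lower number from compound 3 to compound 4 (0.08 log units; within the scatter), is therefore estimated to stay within the scatter. Compound 4 is expected at 3.5 mg/kg, with an estimated range from 1.3 mg/kg to 9 mg/kg.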

Compound 4, dose for half-maximal effect: 2.3 mg/kg
Compound 4: middle estimate off by 1.5-fold (0.18 log units), on the high side; low and high end bracket the measured number.
By their numbers in this assay, from the lowest: compounds 2, 4 and 3 (each within the scatter of the next, the first and the last beyond it); then compound 1.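

In this assay dimethylamino proves about as accommodated at this place as the other groups: a 1.3-fold higher number from compound 2 to compound 4 (0.11 log units; within the scatter) against methylsulfonyl and a 1.8-fold lower number from compound 3 to compound 4 (0.26 log units; within the scatter) against the aromatic ring-bearing group both stay within the scatter. The a 3.9-fold lower number from compound 1 to compound 4 (0.59 log units; beyond the scatter) lies beyond it and sets compound 1 apart from compound 4, as it already stood apart from compound 2. Nothing available explains these numbers. As far as these compounds go, whether a primary amine, a carboxylic acid or a longer chain at this place would fall in the same range remains open.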